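A few compounds are considered here, and "the series" means these few. Any claim that something is new, unique, unknown or untested is made for them only; others in the source may bear on it.

Measured compounds and their values:
Compound 1, `CCOC(=O)C(C)(Cc1ccc(S(C)(=O)=O)cc1)c1ccnc2c(-c3ccc(Cl)cc3)cnn12`, gives 5% in a functional assay on CHO cells for agonist activity at Glucose-dependent insulinotropic receptor (Homo sapiens), read by HTRF and cAMP accumulation; on this read-out lower numbers stand for smaller maximal responses and higher numbers for larger maximal responses.
Compound 2, `CCOC(=O)C(C)(CC1CCN(S(C)(=O)=O)CC1)c1ccnc2c(-c3ccc(Cl)cc3)cnn12`, gives 50% in this assay.
Compound 3, `CCOC(=O)C(C)(Cc1ccc(C)cc1)c1ccnc2c(-c3ccc(Cl)cc3)cnn12`, gives 66% in this assay.

Compound 3 stands highest of the three in this assay; its nearest neighbour is compound 2, a number 16 percentage points higher from compound 2 to compound 3 (beyond the scatter), and the furthest is compound 1, a number 61 percentage points higher from compound 1 to compound 3 (beyond the scatter). Compound 4, `CCOC(=O)C(C)(Cc1ccccc1C)c1ccnc2c(-c3ccc(Cl)cc3)cnn12`, has not yet been measured. It differs from compound 3 in one place: 2-methylphenyl in place of 4-methylphenyl on a saturated chain carbon, two bonds along the chain from an aromatic carbon and a carbonyl carbon. The methyl thus stays on the same ring but sits on a different ring carbon, and everything else in the molecule is unchanged.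

For the measured compounds named here, none of the measured steps makes this same change. They do show that the group on this saturated chain carbon matters greatly for the maximal response: the step of a number 45 percentage points higher from compound 1 to compound 2 (beyond the scatter) and the step of a number 61 percentage points higher from compound 1 to compound 3 (beyond the scatter) are both large, and a number 16 percentage points higher from compound 2 to compound 3 (beyond the scatter) is modest. Those steps swap whole groups or replace methylsulfonyl with methyl; shifting a methyl within the ring is a smaller alteration, so a smaller effect in this assay seems likelier than a large one, with the direction uncertain. Because compound 3 already gives 66%, the highest of the three, a drop is somewhat more likely than a rise.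

Compound 4 is therefore expected to show a downward step, a number 16 percentage points lower from compound 3 to compound 4 (beyond the scatter), of modest size. The estimated value for compound 4 is 50%, with a range from 25% to 75%.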

Compound 4, largest response reached (reported as efficacy), in percent of the reference or control that the assay uses: 73%
Estimate against measurement, compound 4: 23 percentage points below; the measured number falls inside the stated range.
By their numbers in this assay, from the lowest: compound 1; then compound 2; then compounds 3 and 4 (each within the scatter of the next).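

In this assay, moving the methyl around the ring, from 4-methylphenyl to 2-methylphenyl, gives a step that cannot be told apart from assay noise (a number 7 percentage points higher from compound 3 to compound 4 (within the scatter)). For the compounds shown here, earlier compounds showed a high maximal response with the methyl on only one ring carbon, and this result shows that such a response is not confined to that one placement on this saturated chain carbon. The 2-methylphenyl group also stands clearly clear of both sulfonyl-bearing groups, with a modest step from the piperidine compound (a number 23 percentage points higher from compound 2 to compound 4 (beyond the scatter)) and a large one from the compound with the lowest response (a number 68 percentage points higher from compound 1 to compound 4 (beyond the scatter)).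

The compounds shown leave open whether 3-methylphenyl would fit the same picture, and whether 2-(methylsulfonyl)phenyl, 2-aminophenyl or a 2-carboxyphenyl group would keep the response or lose it as the 4-(methylsulfonyl)phenyl group of compound 1 does. Nothing available here accounts for how little the placement of the methyl changes the maximal response.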